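This account rests on a few compounds, and the source may have more. Where it says the series, first, only, none or still open, it means among the compounds named here.

Compound 1 `C/C(=N\NC(=O)COc1cccc2cccnc12)c1ccc(Cl)cc1` was tested in an ADME assay on MCF7 cells (Homo sapiens) for cytotoxicity, read by MTT assay, with a stated time of 48 h; on this read-out higher numbers stand for weaker inhibition and lower numbers for stronger inhibition. In this assay compound 1 gives > 100000 nM, which is a limit of the assay and not a number. Two further compounds belong to the same set: compound 2 `c1ccc(-c2c[se]nn2)cc1` and compound 3 `c1ccc(-c2csnn2)cc1`. For compound 2 the result in this assay is "not determined" (no result reported). For compound 3 the result in this assay is "not determined" (no result reported). Among the compounds with values here, compound 1 therefore stands at the limit of > 100000 nM in this assay, at which 1 of the 3 values shown sits, and no other compound supplies a number to set beside it.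

Compound 4 `C/C(=N\NC(=O)COc1cccc2cccnc12)c1cccs1` has not yet been measured. It differs from compound 1 in one place: thiophen-2-yl in place of 4-chlorophenyl on a carbon with a double bond to nitrogen. No step between two measured compounds is known, so there is no record of how a change of this kind moves the read-out, and the shared core of compound 1 has so far shown no measurable cytotoxicity. Compound 4 is expected to give 100000 nM, between 30000 nM and 300000 nM, most likely reported again as a limit rather than a number. The expected step of a number no higher from compound 1 to compound 4 (the limit leaves the size open) amounts to no change beyond the usual scatter.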

Compound 4, half-maximal inhibitory concentration: > 100000 nM
Compound 4 was reported as a limit; the forecaster's own chance of this, stated with the estimate: 80%; the middle value lies on the limit itself.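

Compound 1 and compound 4 both end at a limit of the assay and not at a number, so the change from 4-chlorophenyl to thiophen-2-yl gives no step that can be read: the limit of > 100000 nM in this assay, at which 2 of the 4 values shown sit.

The compounds shown leave open whether any change at this place would bring the read-out to a measurable number.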